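The source may report more compounds than this note shows. Statements on the series, on what has been measured and on what is new or still open speak of the compounds shown alone.

Three compounds have been measured in a functional assay on A549 cells (Homo sapiens) for cytotoxicity, with a stated time of 48 h; on this read-out lower numbers stand for stronger inhibition and higher numbers for weaker inhibition:

Compound 1 `CC(C)CC(=O)Oc1ccc2oc(/C=C/[S+](C)[O-])cc(=O)c2c1` gives 2300 nM
Compound 2 `C[S+]([O-])/C=C/c1cc(=O)c2cc(O)ccc2o1` gives 10500 nM
Compound 3 `C[S+]([O-])/C=C/c1cc(=O)c2cc(F)ccc2o1` gives 2100 nM

Compound 3 has the lowest of the three numbers, yet its neighbour is compound 1, since a 1.1-fold lower number from compound 1 to compound 3 (0.04 log units; within the scatter), so the two cannot be ranked against each other. Among the measured compounds shown here, compound 2 stands apart: a 5.0-fold lower number from compound 2 to compound 3 (0.70 log units; beyond the scatter), and this is the only step among the three that is clearly beyond the scatter.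

Compound 4 `C[S+]([O-])/C=C/c1cc(=O)c2cc(Cl)ccc2o1` is the next compound to be measured. It differs from compound 3 by chloro in place of fluoro on an aromatic carbon. For the measured compounds named here, no measured step exchanges one halogen for another, so the only steps that bear on this change are the two that end at compound 3: the step from compound 2, which is modest, and the step from compound 1, which is within the scatter. Neither describes the chloro group itself, so the expectation rests on the fluoro analogue alone; the expected change is a 1.2-fold lower number from compound 3 to compound 4 (0.07 log units; within the scatter), with no step beyond the scatter. Compound 4 is therefore estimated at 1800 nM, with a range from 700 nM to 4500 nM.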

Compound 4, half-maximal inhibitory concentration: 1700 nM
Compound 4: middle estimate off by 1.1-fold (0.02 log units), on the high side, and the stated range covers the measured number.
By their numbers in this assay, from the lowest: compounds 4, 3 and 1 (each within the scatter of the next); then compound 2.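

In this assay, among the compounds shown here, this is the first exchange of one halogen for another on this aromatic carbon, and it stays within the scatter (a 1.2-fold lower number from compound 3 to compound 4 (0.09 log units; within the scatter)), as does the exchange of the (isobutylcarbonyl)oxy group for chloro (a 1.4-fold lower number from compound 1 to compound 4 (0.13 log units; within the scatter)). The step away from hydroxy is now seen with a second halogen and is again beyond the scatter (a 6.2-fold lower number from compound 2 to compound 4 (0.79 log units; beyond the scatter)), so among the compounds shown, only the hydroxy group separates from the others at this position. No accompanying measurement offers an explanation for these results.

The compounds shown leave open whether bromo, an amine, a methoxy group or a carboxylic acid on this carbon would give a number beyond the scatter of these three. They also leave open whether chloro would give a similar number on another carbon of the same ring.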